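Compound 4: trifluoromethyl in place of methoxy

The compounds below may be only part of what the source reports. "The series", "measured", "known", "first", "only" and "open" are said of these compounds alone.

In an ADME assay on MT4 cells (Homo sapiens) for cytotoxicity, read by MTT assay, with a stated time of 4 days (a higher number here means that more compound is tolerated, a lower number that less compound is tolerated), compound 1 (`CC(=O)Nc1ccc2oc(-c3ccccc3)c(O)c(=O)c2c1`) gives 64700 nM and compound 2 (`COc1ccc(-c2oc3ccc(NC(C)=O)cc3c(=O)c2O)cc1`) gives 98700 nM while compound 3 (`CC(=O)Nc1ccc2oc(-c3cccc(F)c3)c(O)c(=O)c2c1`) gives 26500 nM on the same read-out. Compound 2 shares the top of this small set. That tie shows in one step (a 1.5-fold higher number from compound 1 to compound 2 (0.18 log units; within the scatter)) and the fluoro member sits lower (a 3.7-fold lower number from compound 2 to compound 3 (0.57 log units; beyond the scatter)). Compound 4 (`CC(=O)Nc1ccc2oc(-c3ccc(C(F)(F)F)cc3)c(O)c(=O)c2c1`) carries trifluoromethyl in place of methoxy on an aromatic carbon para to a large group. Among the compounds with values here, no measured step makes this exchange. The closest guide is fluoro in place of hydrogen (a 2.4-fold lower number from compound 1 to compound 3 (0.39 log units; beyond the scatter)) which was modest. A modest step to a lower number is therefore expected (a 2.4-fold lower number from compound 2 to compound 4 (0.37 log units; beyond the scatter)) and nothing larger. Compound 4 is estimated at 42000 nM with an expected range from 16000 nM to 100000 nM in this assay.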

Compound 4, half-maximal cytotoxic concentration: 7300 nM
Compound 4: middle estimate off by 5.8-fold (0.76 log units), on the high side; the whole stated range lies above it.
By their numbers in this assay, from the lowest: compound 4; then compound 3; then compounds 1 and 2 (each within the scatter of the next).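

At this aromatic carbon, para to a large group, the position is not indifferent to substitution: the step from hydrogen to methoxy stayed within the scatter in this assay, while trifluoromethyl gives an 8.9-fold lower number from compound 1 to compound 4 (0.95 log units; beyond the scatter). The direct exchange is larger still, with a 14-fold lower number from compound 2 to compound 4 (1.13 log units; beyond the scatter), so the identity of the group here can move the tolerated concentration well beyond the scatter.

From the compounds shown here alone, whether a chloro group, a nitrile or an amine at this carbon would also lower the number remains open. No available measurement gives a reason for the drop.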